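The source may report more compounds than this note shows. Statements on the series, on what has been measured and on what is new or still open speak of the compounds shown alone.

Series notes. In a functional assay on MGC-803 cells (Homo sapiens) for antiproliferative activity, read by CellTiter-Glo, with a stated time of 72 h (a lower number here means a stronger inhibitor, a higher number a weaker inhibitor), compound 1 `O=C(NO)c1ccc(/C=C/c2ccnc(-c3ccccc3O)c2)cc1` gives 1420 nM. Compound 2 `Cc1ccc(-c2cc(/C=C/c3ccc(C(=O)NO)cc3)ccn2)c(F)c1` gives 770 nM in this assay. Compound 3 `Cc1ccc(-c2cncc(/C=C/c3ccc(C(=O)NO)cc3)c2)c(F)c1` gives 2240 nM in this assay, a higher number than that of compound 2; how the cores of compound 2 and compound 3 differ is not broken down here. Within the data shown here, the single counted change between compound 2 and compound 1, (2-hydroxyphenyl in place of 2-fluoro-4-methylphenyl on an aromatic carbon), gives a 1.8-fold higher number from compound 2 to compound 1 (0.27 log units; within the scatter).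

Compound 4 `O=C(NO)c1ccc(/C=C/c2cncc(-c3ccccc3O)c2)cc1` has not yet been measured in this assay. It carries the same kind of change on the core of compound 3, (2-hydroxyphenyl in place of 2-fluoro-4-methylphenyl on an aromatic carbon); the place is not the same, since in compound 1 the group sits next to the ring nitrogen and in compound 4 two atoms from the ring nitrogen. The step expected here, a 1.7-fold higher number from compound 3 to compound 4 (0.23 log units; within the scatter), is set beside a 1.8-fold higher number from compound 2 to compound 1 (0.27 log units; within the scatter) and rests on that one measured pair alone, with the shifted place widening the uncertainty. Compound 4 is therefore estimated at 3800 nM in this assay, with a range from 1600 nM to 9000 nM.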

Compound 4, half-maximal inhibitory concentration: 5460 nM
The estimate for compound 4 lay 1.4-fold (0.16 log units) below the measured number, and the stated range covers the measured number.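

In this assay, setting 2-hydroxyphenyl in place of 2-fluoro-4-methylphenyl, on an aromatic carbon two atoms from the ring nitrogen, gives a 2.4-fold higher number from compound 3 to compound 4 (0.39 log units; beyond the scatter). The change therefore carries over in the same direction, and the two steps do not differ in size beyond what repeated measurement allows: the same change on two cores in this assay, a 1.8-fold higher number (0.27 log units; within the scatter) from compound 2 to compound 1 and a 2.4-fold higher number (0.39 log units; beyond the scatter) from compound 3 to compound 4, 1.3-fold (0.12 log units) apart, within the scatter of two such steps
This agreement rests on two pairs only, one step within the scatter and one beyond it, and the group also sits at a different place in each pair, so the data neither separate core from place nor show that the step would hold on any further core.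

Each pair swaps the whole aryl group, which leaves open how much of the step belongs to the fluoro and how much to the methyl substituent. Also open, on these data alone, is whether an amine or a carboxylic acid on the same phenyl ring would follow the same step on either core.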